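The compounds below may be only part of what the source reports. "The series", "measured", "known", "first", "only" and "open" are said of these compounds alone.

Compound 1, `CCC(=O)Nc1ccc(C(=O)Nc2ccc(C)c(Nc3nccc(-c4cccnc4)n3)c2)cc1`: in an ADME assay on BaF3 cells (Mus musculus) for cytotoxicity, read by CellTiter-Glo and CCK-8 assay, with a stated time of 72 h (a lower number here means a stronger inhibitor of growth, a higher number a weaker inhibitor of growth), compound 1 gives > 10000 nM, a limit of the assay and not a number.
Compound 2, `C=CC(=O)Nc1cccc(C(=O)Nc2ccc(C)c(Nc3nccc(-c4cccnc4)n3)c2)c1`: in this assay compound 2 gives 2480 nM.

Compound 1 thus sits at the limit of > 10000 nM in this assay, at which 1 of the 2 values shown sits. Compound 3, `C/C=C/C(=O)N(CCN(C)C)Cc1ccc(C(=O)Nc2ccc(C)c(Nc3nccc(-c4cccnc4)n3)c2)cc1`, differs from it by ((2-(dimethylamino)ethyl)((prop-1-en-1-yl)carbonyl)amino)methyl in place of propanoylamino on an aromatic carbon. Going by the values given here, the one measured step that bears on this is an at least 4.0-fold lower number from compound 1 to compound 2 (0.60 log units; beyond the scatter), where a group carrying a carbon-carbon double bond on the carbonyl also entered; the change to compound 3 brings such a double bond too, so a lower number of similar size is expected. Compound 3 is estimated at 3000 nM (range 800 nM to 12000 nM), a step of an at least 3.3-fold lower number from compound 1 to compound 3 (0.52 log units; beyond the scatter).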

Compound 3, concentration for 50% growth inhibition: > 10000 nM
Compound 3: only a limit was reported; the forecaster's own chance of this, stated with the estimate: 25%; at least 3.3-fold (0.52 log units) between middle value and limit.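

In this assay, going by these compounds alone, compound 3, like compound 1, stands at a limit and not a number, so no step between them can be read: the limit of > 10000 nM in this assay, at which 2 of the 3 values shown sit. The compounds shown leave open how far apart compound 1 and compound 3 lie in growth inhibition, and whether the change between them shifts it at all.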